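The source may hold more compounds than are shown below. What is called first, only, known or untested is meant among the compounds shown, and "the series" means these compounds.

In a functional assay on A549 cells (Homo sapiens) for antiproliferative activity, read by MTT assay, with a stated time of 48 h (a higher number here means a weaker inhibitor, a lower number a stronger inhibitor), compound 1 `O=C(/C=C/c1ccccc1)Nc1nnc(-c2ccccc2)s1` gives 1.75 ug/mL and sits among its two measured relatives, all three lying within the scatter of one another. Compound 2 `Cc1ccc(/C=C/C(=O)Nc2nnc(-c3ccccc3)s2)cc1` gives 1.58 ug/mL in this assay and compound 3 `O=C(/C=C/c1ccc(F)cc1)Nc1nnc(-c2ccccc2)s1` gives 1.82 ug/mL in this assay as well. Compound 4 `O=C(/C=C/c1ccccc1)Nc1nnc(-c2ccc(Cl)cc2)s1` has not yet been measured. Its change from compound 1 is chloro in place of hydrogen on an aromatic carbon and this turns phenyl into 4-chlorophenyl.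

The measured steps bear on this only loosely. Methyl in place of hydrogen gave a 1.1-fold lower number from compound 1 to compound 2 (0.04 log units; within the scatter) while fluoro in place of hydrogen gave a 1.0-fold higher number from compound 1 to compound 3 (0.02 log units; within the scatter) and fluoro in place of methyl gave a 1.2-fold higher number from compound 2 to compound 3 (0.06 log units; within the scatter) so none of these steps left the scatter. All three fall on the other aromatic ring, not the one that carries the chloro in compound 4, and the data therefore hold no direct measure at that site. Judged from these small steps, no change beyond the scatter is expected, and the estimated step is a 1.1-fold lower number from compound 1 to compound 4 (0.04 log units; within the scatter) with no firm direction. Compound 4 is expected at 1.6 ug/mL within an estimated range of 0.75 ug/mL to 3.2 ug/mL on this reading.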

Compound 4, half-maximal inhibitory concentration: 2.02 ug/mL
Beside the measured number, compound 4's estimate is 1.3-fold (0.10 log units) below it; the measured number falls inside the stated range.
By their numbers in this assay, from the lowest: compounds 2, 1, 3 and 4 (each within the scatter of the next).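

Compound 4 is the first of these compounds with a change on the phenyl that compound 1, compound 2 and compound 3 all carry unaltered, so it gives the first reading at this site. In this assay, turning that phenyl into 4-chlorophenyl gives a 1.2-fold higher number from compound 1 to compound 4 (0.06 log units; within the scatter), which means that a chloro on an aromatic carbon, para to a large group, leaves the number where it was. The step stays within the scatter, as the methyl and fluoro steps on the other aromatic ring do, so neither ring has yet shown a change that moves the number, and no measurement offered here speaks to why the site behaves this way.

A single halogen is all that the compounds shown offer at this site, so it remains open whether an amine, a carboxylic acid or a longer chain in the same place would move the number beyond the scatter. From the compounds shown here alone, it also remains open whether the chloro on this ring, paired with a methyl or a fluoro on the other ring, would read any differently from either change alone.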